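The source may hold more compounds than are shown below. What is called first, only, known or untested is meant among the compounds shown, and "the series" means these compounds.

Measured compounds:
- compound 1, `O=C1/C(=C/c2ccccc2F)CN(C(=S)SCc2cn(Cc3ccccc3Cl)nn2)C/C1=C\c1ccccc1F`: 43600 nM
- compound 2, `Cc1ccc(/C=C2\CN(C(=S)SCc3cn(Cc4ccccc4F)nn3)C/C(=C\c3ccc(C)cc3)C2=O)cc1`: 28400 nM
- compound 3, `Cc1ccc(/C=C2\CN(Cc3cn(Cc4cccc(Cl)c4)nn3)C/C(=C\c3ccc(C)cc3)C2=O)cc1`: 29300 nM

All three were tested in a functional assay on 4T1 cells (Mus musculus) for cytotoxicity, read by MTT assay, with a stated time of 24 h; on this read-out higher numbers stand for weaker inhibition and lower numbers for stronger inhibition. Among the compounds with values here, compound 2 gives 28400 nM, the lowest of the three numbers, yet compound 3 at 29300 nM and compound 1 at 43600 nM both lie within the usual scatter of it, so the three read as essentially alike and no compound can be called stronger than another.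

Compound 4, `Cc1ccc(/C=C2\CN(C(=S)SCc3cn(Cc4ccccc4Cl)nn3)C/C(=C\c3ccc(C)cc3)C2=O)cc1`, has not yet been measured. It differs from compound 2 in one place: chloro in place of fluoro on an aromatic carbon. The change sits on a benzyl group attached to the triazole, away from the shared core.

Within the data shown here, no step between measured compounds is available, so the expectation rests on the three values alone, which all sit close together despite differences at this very position. The step from compound 2 to compound 4 is expected to be a 1.1-fold higher number from compound 2 to compound 4 (0.02 log units; within the scatter), that is, nothing beyond the scatter. Compound 4 is therefore estimated at 30000 nM in this assay, with a range from 15000 nM to 60000 nM.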

Compound 4, half-maximal inhibitory concentration: 49300 nM
Beside the measured number, compound 4's estimate is 1.6-fold (0.22 log units) below it, within the range that was stated.
By their numbers in this assay, from the lowest: compounds 2, 3, 1 and 4 (each within the scatter of the next).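

Within the data shown here, compound 2 and compound 4 give the first comparison here that changes one place and holds the rest of the molecule fixed. In this assay, going from 2-fluorobenzyl to 2-chlorobenzyl gives a 1.7-fold higher number from compound 2 to compound 4 (0.24 log units; within the scatter), so fluoro and chloro on this aromatic carbon cannot be told apart. Nothing available explains the size of this step.

Going by these compounds, it remains open how this position responds to a group other than these two halogens, such as a methoxy group, an amine or a carboxylic acid on the same carbon. On these data alone, it is also open whether fluoro and chloro would still read as alike with other groups elsewhere on the shared core; compound 1 and compound 3 each differ from compound 2 and compound 4 in more than one place, so they cannot settle this.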